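The source may report more compounds than this note shows. Statements on the series, on what has been measured and on what is new or still open speak of the compounds shown alone.

Series notes, pyrazolopyrimidine thioethers with a shared core.

Compound 1 `CC(C)c1n[nH]c2c(NCc3ccc(-c4ccccn4)cc3)nc(SCCC(N)=O)nc12` carries a carbamoylmethyl group on a saturated chain carbon bound to a sulfur. In a functional assay on HT cells (Homo sapiens) for antiproliferative activity, read by fluorescence, with a stated time of 72 h (on this read-out lower numbers stand for stronger inhibition of growth and higher numbers for weaker inhibition of growth), compound 1 gives 120 nM. Compound 2 `CC(C)c1n[nH]c2c(NCc3ccc(-c4ccccn4)cc3)nc(SCC(N)CN)nc12` carries a 1,2-diaminoethyl group in the same place; in this assay compound 2 gives 480 nM. Going by the values given here, the only step so far, a 4.0-fold higher number from compound 1 to compound 2 (0.60 log units; beyond the scatter), is a modest worsening that lies beyond the scatter. On the two numbers shown, compound 2 stands highest, with compound 1 the nearer and only neighbour.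

The next compound, compound 3 `CC(C)c1n[nH]c2c(NCc3ccc(-c4ccccn4)cc3)nc(SCC(O)CN3CCNCC3)nc12`, differs from compound 2 in one place: 1-hydroxy-2-(piperazin-1-yl)ethyl in place of 1,2-diaminoethyl on a saturated chain carbon bound to a sulfur. Among the compounds with values here, no measured step covers a change of this kind; the one known step concerns the switch from carbamoylmethyl to 1,2-diaminoethyl and says nothing direct about a hydroxy-piperazinyl chain. The expectation can therefore only be anchored on compound 2 and widened to cover the uncertainty. No step beyond the scatter is expected in either direction, so the estimated step from compound 2 is a 1.2-fold lower number from compound 2 to compound 3 (0.08 log units; within the scatter). Compound 3 is accordingly estimated at 400 nM, with a range from 130 nM to 1300 nM.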

Compound 3, concentration for 50% growth inhibition: 332 nM
Estimate against measurement, compound 3: 1.2-fold (0.08 log units) above; the measured number falls inside the stated range.
By their numbers in this assay, from the lowest: compound 1; then compounds 3 and 2 (each within the scatter of the next).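

The position on a saturated chain carbon bound to a sulfur accepts a much larger group, with 9 heavy atoms and a six-membered non-aromatic ring in place of 4 heavy atoms and no ring, without a step beyond the scatter: a 1.4-fold lower number from compound 2 to compound 3 (0.16 log units; within the scatter) in this assay. The comparison with the amide-bearing chain gives a 2.8-fold higher number from compound 1 to compound 3 (0.44 log units; beyond the scatter), so compound 1 now has a number lower than those of both other compounds by more than the scatter, and neither replacement chain matches it in this read-out. No measurement of any property or other supporting data accompanies these numbers, so the result cannot be explained here.

Compound 2 and compound 3 differ in both the hydroxy group and the piperazine ring, so the contribution of each remains unresolved, and a 3-(piperazin-1-yl)propyl or 2-hydroxy-3-(morpholin-4-yl)propyl chain would be needed to separate them. Also open, going by these compounds, is how a carboxylic acid, or a longer chain ending in the primary amide, would compare with compound 1 at this position.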